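A few compounds are considered here, and "the series" means these few. Any claim that something is new, unique, unknown or untested is made for them only; others in the source may bear on it.

Measured compounds:
compound 1, `COCCC(=O)N[C@@H]1CC[C@@H](Nc2ncc3c(Br)nn(-c4ccc5ncccc5c4)c3n2)C1`, 159 nM
compound 2, `COCCNC(=O)[C@H]1CC[C@@H](Nc2ncc3c(Br)nn(-c4ccc5ncccc5c4)c3n2)CC1`, 763 nM
compound 3, `COCCNC(=O)[C@H]1CC[C@H](Nc2ncc3c(Br)nn(-c4ccc5ncccc5c4)c3n2)CC1`, 628 nM

All three were tested in an assay on SK-OV-3 cells for inhibition of eIF-2-alpha kinase GCN2 (Homo sapiens); a higher number here means a weaker inhibitor, a lower number a stronger inhibitor. Compound 1 gives the lowest number of the three, and its gaps to compound 2 and to compound 3 lie beyond the scatter. Compounds 2 and 3 are mirror images, and the step of a 1.2-fold lower number from compound 2 to compound 3 (0.08 log units; within the scatter) stays within the scatter, which fits (the fact that compounds 2 and 3 differ only in the configuration as drawn).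

Compound 4, `CNC(=O)[C@@H]1CC[C@@H](Nc2ncc3c(Br)nn(-c4ccc5ncccc5c4)c3n2)C1`, is compound 1 with methylcarbamoyl in place of ((2-methoxyethyl)carbonyl)amino on a saturated ring carbon. Within the data shown here, no measured pair differs in exactly this way, so the only guidance is that compound 2 and compound 3, which carry their amide attached through carbon rather than nitrogen, give weaker numbers than compound 1. A modest weakening is therefore expected: a 2.2-fold higher number from compound 1 to compound 4 (0.34 log units; beyond the scatter). For compound 4 the estimate in this assay is 350 nM, between 120 nM and 1000 nM.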

Compound 4, half-maximal inhibitory concentration: 25 nM
Compound 4: middle estimate off by 14-fold (1.15 log units), on the high side; measured number below the stated range.
By their numbers in this assay, from the lowest: compound 4; then compound 1; then compounds 3 and 2 (each within the scatter of the next).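

The step of a 6.4-fold lower number from compound 1 to compound 4 (0.80 log units; beyond the scatter) shows that on this saturated ring carbon, methylcarbamoyl, the smaller group with its amide attached through carbon, goes with a stronger inhibitor in this assay. Amide attachment and group size change together here, so this single step cannot divide the gain between them. Nothing known from these compounds explains the gain.

Open, from the compounds shown here alone, is which of the two changes matters. Acetylamino on this ring carbon would keep the nitrogen attachment of compound 1 with a shorter chain, and ethylcarbamoyl would test a longer chain on the carbon attachment of compound 4.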